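A few compounds are considered here, and "the series" means these few. Any claim that something is new, unique, unknown or untested is made for them only; others in the source may bear on it.

Measured compounds:
compound 1, `O=S(=O)(CC1=NCCO1)C1C(c2ccc(Cl)cc2)=NN(c2ccccc2)C1c1ccc(Cl)cc1`, gives "not active" (no number reported) in a functional assay, tested at 50 ug/mL; a higher number here means a stronger effect of the compound at the concentration tested, a lower number a weaker effect.
compound 2, `COc1ccc(C2=NN(c3ccccc3)C(c3ccc(C)cc3)C2S(=O)(=O)CC2=NCCO2)cc1`, gives 62.5% in this assay.
compound 3, `COc1ccc(C2=NN(c3ccccc3)C(c3ccc(C)cc3)C2S(=O)(=O)CC2=NCCS2)cc1`, gives 42.6% in this assay.

Compound 1 and compound 2 carry different cores; the difference between the two cores is not broken down here. Within the core of compound 2, the change from compound 2 to compound 3 is a group of 5 heavy atoms (3 carbon, 1 nitrogen, 1 sulfur; one five-membered non-aromatic ring with 2 hetero atoms) in place of a group of 5 heavy atoms (3 carbon, 1 nitrogen, 1 oxygen; one five-membered non-aromatic ring with 2 hetero atoms), on a saturated chain carbon bound to a sulfonyl sulfur. This change brings a number 19.9 percentage points lower from compound 2 to compound 3 (beyond the scatter) in this assay, a modest loss that lies beyond the scatter.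

Compound 4, `O=S(=O)(CC1=NCCS1)C1C(c2ccc(Cl)cc2)=NN(c2ccccc2)C1c1ccc(Cl)cc1`, is not yet measured. It arises from compound 1 by a group of 5 heavy atoms (3 carbon, 1 nitrogen, 1 sulfur; one five-membered non-aromatic ring with 2 hetero atoms) in place of a group of 5 heavy atoms (3 carbon, 1 nitrogen, 1 oxygen; one five-membered non-aromatic ring with 2 hetero atoms), on a saturated chain carbon bound to a sulfonyl sulfur, the same change as that from compound 2 to compound 3, at the same place. Going by the values given here, compound 1 itself gives no number in this assay; it is reported as not active, so no step from compound 1 to compound 4 can be computed.

The expectation for compound 4 rests on two things: compound 1 gives "not active" (no number reported) in this assay, and the same change lowered the read-out from compound 2 to compound 3 by a number 19.9 percentage points lower from compound 2 to compound 3 (beyond the scatter). Among the compounds with values here, nothing among the measured compounds suggests that this change raises the read-out on either core. The read-out of compound 4 in this assay is therefore expected to be low, around 10%, most likely between 0% and 30%, and a report of no number at all is considered likely.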

Compound 4, a percentage reported as activity, at one concentration (the size of the read-out at that concentration, not a potency): "not active" (no number reported)
For compound 4 the study gives words and no number; there is nothing to compare the estimate with.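

In this assay, going by these compounds alone, compound 1 gives "not active" (no number reported) and compound 4 gives "not active" (no number reported) so no step from compound 1 to compound 4 can be read. The compounds shown leave open whether exchanging the oxygen-containing five-membered ring for the sulfur-containing one changes the read-out at all on the core of compound 1. No measurement shown bears on this result.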